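Replacing an Aryl Triazole Substituent with Hydroxymethyl

The source may hold more compounds than are shown below. What is called first, only, known or untested is meant among the compounds shown, and "the series" means these compounds.

Of the compounds shown here, three built on the same core have been measured in an ADME assay on HeLa cells (Homo sapiens) for cytotoxicity, read by sulforhodamine B assay, with a stated time of 48 h, tested at 10 uM; a higher number here means more inhibition at the concentration tested (going by the name of the read-out), a lower number less inhibition. Compound 1 `CCOC(=O)c1cn(C(c2ccccc2)c2cc3cc(Br)ccc3nc2OC)nn1` gives -3.67% in this assay; compound 2 `CCCCCc1cn(C(c2ccccc2)c2cc3cc(Br)ccc3nc2OC)nn1` gives -9.81%; and compound 3 `COc1nc2ccc(Br)cc2cc1C(c1ccccc1)n1cc(-c2ccc(OC(F)(F)F)cc2)nn1` gives -2.24%. All three numbers sit close to zero, so none of these compounds shows measurable cytotoxicity at the concentration tested. Compound 3 has the highest of the three numbers, but it stands apart from neither neighbour: a number 1.4 percentage points higher from compound 1 to compound 3 (within the scatter) and a number 7.6 percentage points higher from compound 2 to compound 3 (within the scatter), and likewise a number 6.1 percentage points lower from compound 1 to compound 2 (within the scatter).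

Compound 4 `COc1nc2ccc(Br)cc2cc1C(c1ccccc1)n1cc(CO)nn1` has not yet been measured. It differs from compound 3 in one place: hydroxymethyl in place of 4-(trifluoromethoxy)phenyl on an aromatic carbon. Within the data shown here, no measured step exchanges the 4-(trifluoromethoxy)phenyl group for a hydroxymethyl group, so the nearest guidance comes from the two steps that installed that aryl group, from ethoxycarbonyl and from pentyl, each of which stayed within the scatter. Since every substituent tried at this position of the triazole left the read-out near zero, a step of no consequence beyond the scatter is expected for compound 4, expressed as a number 1.8 percentage points lower from compound 3 to compound 4 (within the scatter). Compound 4 is therefore estimated to give -4% in this assay, with a range from -14% to 8%.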

Compound 4, a percentage reported as inhibition, at one concentration (the size of the read-out at that concentration, not a potency): 0.25%
Estimate against measurement, compound 4: 4.3 percentage points below; measured number inside the range.
By their numbers in this assay, from the lowest: compounds 2, 1, 3 and 4 (each within the scatter of the next, the first and the last beyond it).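

In this assay, hydroxymethyl, with 2 heavy atoms, no ring and 1 hydrogen-bond donor, takes the place of the much larger 4-(trifluoromethoxy)phenyl with no step beyond the scatter (a number 2.5 percentage points higher from compound 3 to compound 4 (within the scatter)), and the same holds for its exchange with ethoxycarbonyl (a number 3.9 percentage points higher from compound 1 to compound 4 (within the scatter)), so on this aromatic carbon neither an aromatic ring nor a substituent of that size is needed to keep the read-out where it stands. The step from pentyl is the first among these compounds to pass the scatter (a number 10.1 percentage points higher from compound 2 to compound 4 (beyond the scatter)), but it is modest and links only the two ends of the series, with compound 2 at (-9.81%) and compound 4 at (0.25%) both still close to zero. Nothing measured here explains why this one step reaches beyond the scatter.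

The compounds shown leave open whether the hydroxyl itself matters, which a methyl ether in its place would test. They also leave open whether an aminomethyl group, a carboxylic acid or a longer hydroxyalkyl chain on this carbon would lift the read-out clearly away from zero.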